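A few compounds are considered here, and "the series" means these few. Any claim that something is new, unique, unknown or untested is made for them only; others in the source may bear on it.

Measured so far:
Compound 1 `CC(=O)O[C@@H]1OC(=O)[C@@](C(C)=O)(C2SCCCS2)[C@@H]1C` — in a functional assay on MCF7 cells (Homo sapiens) for cytotoxicity, read by MTT assay (on this read-out lower numbers stand for stronger inhibition and higher numbers for weaker inhibition), compound 1 gives > 50000 nM, which is a limit of the assay and not a number.
Compound 2 `CC(=O)O[C@@H]1OC(=O)[C@](OC(C)=O)(C(C)=O)[C@@H]1C` — in this assay compound 2 gives > 50000 nM, likewise a limit.

Among the compounds with values here, compound 2 thus stands only at a limit, and the one other value shown is also a limit, as noted in the limit of > 50000 nM in this assay, at which 2 of the 2 values shown sit. The step that the two limits leave unreadable from compound 1 to compound 2 cannot be read; both of its ends are limits.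

Compound 3 `CC(=O)O[C@@H]1OC(=O)[C@@H](C(C)=O)[C@@H]1C` differs from compound 2 by hydrogen in place of acetoxy on a saturated ring carbon. Within the data shown here, no measured step bears on this change, and the single step available has no readable size or direction. The expectation for compound 3 is therefore no step beyond the scatter, with the number most probably reported again as a limit. The step from compound 2 to compound 3 is expected to be a number no higher from compound 2 to compound 3 (the limit leaves the size open). Compound 3 is estimated at 50000 nM, between 20000 nM and 200000 nM.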

Compound 3, half-maximal inhibitory concentration: > 50000 nM
Compound 3: a limit, no number (the forecaster's own chance of this, stated with the estimate: 80%); the middle value sits exactly at the limit.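

In this assay compound 3 gives > 50000 nM, a limit and not a number. No step among compound 1, compound 2 and compound 3 can be read, as all three values are limits: the limit of > 50000 nM in this assay, at which 3 of the 3 values shown sit.

The compounds shown leave open whether any group on this saturated ring carbon changes the read-out at all.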